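Two fluorines on the phenyl ring of a piperidine core

The compounds below may be only part of what the source reports. "The series", "measured", "known", "first", "only" and "open" are said of these compounds alone.

Of the compounds shown here, three sharing one core have been measured in a functional assay on CHO cells for positive allosteric modulation of metabotropic glutamate receptor 2 (Homo sapiens), with a stated time of 30 min; a lower number here means that less compound is needed, a higher number that more compound is needed for the effect. Compound 1 `N#Cc1c(N2CCC(c3ccccc3)CC2)ccn(CC2CC2)c1=O` carries an unsubstituted phenyl on the saturated ring and gives 151 nM. Compound 2 `N#Cc1c(N2CCC(c3ccccc3Cl)CC2)ccn(CC2CC2)c1=O` gives 49 nM, and compound 3 `COc1ccc(C2CCN(c3ccn(CC4CC4)c(=O)c3C#N)CC2)cc1` gives 98 nM. Compound 3 thus sits in the middle of the three numbers, separated from compound 1 by a 1.5-fold lower number from compound 1 to compound 3 (0.19 log units; within the scatter) and from compound 2 by a 2.0-fold higher number from compound 2 to compound 3 (0.30 log units; within the scatter).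

Compound 4 `N#Cc1c(N2CCC(c3ccc(F)cc3F)CC2)ccn(CC2CC2)c1=O` differs from compound 3 in one place: 2,4-difluorophenyl in place of 4-methoxyphenyl on a saturated ring carbon.

Within the data shown here, two measured steps bear on this. Swapping one substituted phenyl for another, from compound 2 to compound 3, gave only a 2.0-fold higher number from compound 2 to compound 3 (0.30 log units; within the scatter). Putting a halogen onto the phenyl, from compound 1 to compound 2, gave a 3.1-fold lower number from compound 1 to compound 2 (0.49 log units; beyond the scatter). Two fluorines might behave like that chloro, or like the methoxy. Compound 4 is therefore expected to show a modest move toward lower numbers, a 1.6-fold lower number from compound 3 to compound 4 (0.21 log units; within the scatter), with an estimated value of 60 nM and a likely range from 25 nM to 150 nM.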

Compound 4, half-maximal effective concentration: 68 nM
Compound 4: the middle estimate sits 1.1-fold (0.05 log units) below what was measured; measured number inside the range.
By their numbers in this assay, from the lowest: compounds 2, 4, 3 and 1 (each within the scatter of the next, the first and the last beyond it).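

In this assay, compound 4 is the only compound shown with two halogens on the phenyl, and this 2,4-difluorophenyl cannot be told apart from either earlier substituted phenyl: a 1.4-fold lower number from compound 3 to compound 4 (0.16 log units; within the scatter) and a 1.4-fold higher number from compound 2 to compound 4 (0.14 log units; within the scatter). Against the unsubstituted phenyl the change does lie beyond the scatter, with a 2.2-fold lower number from compound 1 to compound 4 (0.35 log units; beyond the scatter), so fluorine joins chloro as a halogen that gives a lower number than phenyl at this saturated ring carbon, while the 4-methoxyphenyl of compound 3 stays within the scatter of phenyl. Nothing available gives a cause for this result.

The compounds shown leave open whether a single fluorine on the phenyl would be enough, or whether both are needed. They also leave open how a phenyl carrying an amine or a carboxylic acid would behave at this place.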